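Swapping a Spiro Ring for a Fused Benzene Ring

This account rests on a few compounds, and the source may have more. Where it says the series, first, only, none or still open, it means among the compounds named here.

Measured so far:
Compound 1 `COc1ccc2[nH]c(C(=O)N3CC(=O)N(Cc4ccccc4)[C@@H](CN4CCCCC4)C3)cc2c1` gives > 25000 nM in a physicochemical assay for solubility, read by spectrophotometry, in phosphate buffer, with a stated time of 2 h, at pH 7.4; a higher number here means a more soluble compound, a lower number a less soluble compound; this value is a limit of the assay, not a number.
Compound 2 `COc1ccc2[nH]c(C(=O)N3CC(=O)N(Cc4ccccc4)[C@@H](CN4CCC5(CCCC5)CC4)C3)cc2c1` gives 5000 nM in this assay.

Among the values shown, compound 2 carries the only actual number; the other value is a limit (the limit of > 25000 nM in this assay, at which 1 of the 2 values shown sits). Compound 3 `COc1ccc2[nH]c(C(=O)N3CC(=O)N(Cc4ccccc4)[C@@H](CN4CCc5ccccc5C4)C3)cc2c1` differs from compound 2 in one place: a group of 10 heavy atoms (9 carbon, 1 nitrogen; one six-membered non-aromatic ring with 1 hetero atom, one six-membered aromatic ring of carbon only) in place of a group of 10 heavy atoms (9 carbon, 1 nitrogen; one five-membered non-aromatic ring of carbon only, one six-membered non-aromatic ring with 1 hetero atom), on a saturated chain carbon bound to a saturated ring carbon. Among the measured compounds shown here, only one measured step touches this part of the molecule: an at least 5.0-fold lower number from compound 1 to compound 2 (0.69 log units; beyond the scatter). In that step a larger group replaced a smaller one on the same chain carbon, and solubility fell. For the change to compound 3, the group that enters matches the group that leaves in size, as the counted atoms show, so no large shift is expected. The step from compound 2 to compound 3 is estimated as no change at the digits printed from compound 2 to compound 3 (within the scatter), within the usual scatter. Compound 3 is therefore expected to give about 5000 nM in this assay, with a likely range from 1500 nM to 15000 nM.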

Compound 3, solubility: 9000 nM
For compound 3 the middle estimate is 1.8-fold (0.26 log units) below the measured one; measured number inside the range.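

In this assay, 1,2,3,4-tetrahydroisoquinolin-2-yl in place of the group in compound 2 gives a 1.8-fold higher number from compound 2 to compound 3 (0.26 log units; within the scatter), so at this position an aromatic ring in place of a five-membered carbon ring makes no readable difference between two groups of matching counted size. Set against piperidin-1-yl, the same group gives an at least 2.7-fold lower number from compound 1 to compound 3 (0.44 log units; beyond the scatter), which makes it the second larger group on this saturated chain carbon to sit on the lower side of compound 1. The value of compound 1 is a limit, not a number, so neither step from it has a known full size: the limit of > 25000 nM in this assay, at which 1 of the 3 values shown sits.

From the compounds shown here alone, whether size alone sets the fall remains open, and a morpholine ring at this place, of similar size to piperidine but with an added oxygen, would test a different kind of change. A smaller amine such as dimethylamino would show how the trend runs in the other direction.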